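The source may hold more compounds than are shown below. What is called first, only, known or untested is meant among the compounds shown, and "the series" means these compounds.

Measured so far in a functional assay on HL-60 cells (Homo sapiens) for inhibition, read by CCK-8 assay, with a stated time of 48 h, tested at 20 uM (on this read-out higher numbers stand for more inhibition of growth at the one concentration tested and lower numbers for less inhibition of growth), are three compounds.

Compound 1 `COc1ccc(Cc2nnc(NC(=O)/C(C#N)=C/c3ccccc3OS(=O)(=O)c3ccc([N+](=O)[O-])cc3)s2)cc1` gives 51%
Compound 2 `Cc1ccc(S(=O)(=O)Oc2ccccc2/C=C(\C#N)C(=O)Nc2nnc(Cc3cccc4ccccc34)s2)cc1` gives 19%
Compound 3 `COc1ccc(S(=O)(=O)Oc2ccccc2/C=C(\C#N)C(=O)Nc2nnc(Cc3cccc4ccccc34)s2)cc1` gives 98%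

Compound 3 stands highest of the three, clearly beyond the scatter of the other two. Compound 4 `N#C/C(=C\c1ccccc1OS(=O)(=O)c1ccc([N+](=O)[O-])cc1)C(=O)Nc1nnc(Cc2cccc3ccccc23)s1` differs from it in one place, (nitro in place of methoxy on an aromatic carbon), with nitro in place of methoxy on an aromatic carbon. Among the compounds with values here, the only measured step at this place, a number 79 percentage points higher from compound 2 to compound 3 (beyond the scatter), was large, but it involved no nitro. Compound 1 carries the same (4-nitrophenyl)sulfonyl group and differs from compound 4 elsewhere. Compound 1 gives 51%. A sizeable fall is therefore expected in this assay, an estimated a number 38 percentage points lower from compound 3 to compound 4 (beyond the scatter). Compound 4 is estimated at 60%, with an expected range of 25% to 95%.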

Compound 4, percent growth inhibition at one concentration: 18%
Compound 4: middle estimate off by 42 percentage points, on the high side, outside the stated range (below it).
By their numbers in this assay, from the lowest: compounds 4 and 2 (each within the scatter of the next); then compound 1; then compound 3.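

In this assay, on this aromatic carbon para to a large group, nitro in place of methoxy gives a number 80 percentage points lower from compound 3 to compound 4 (beyond the scatter), while nitro in place of methyl gives a number 1 percentage points lower from compound 2 to compound 4 (within the scatter), so among these three groups only methoxy stands apart. With the (4-nitrophenyl)sulfonyl group held constant, naphthalen-1-yl in place of 4-methoxyphenyl gives a number 33 percentage points lower from compound 1 to compound 4 (beyond the scatter). No measurement here explains these differences.

Going by these compounds, it remains open whether an amine or a chlorine at this place would read like methoxy or like methyl and nitro.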